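The source may hold more compounds than are shown below. What is called first, only, known or untested is meant among the compounds shown, and "the series" means these compounds.

Compounds 1, 2 and 3 share one core and differ only in the aromatic group that hangs from the double-bonded chain carbon. Compound 1 is `CCOC(=O)C1=C(Nc2ccccc2)S/C(=C\c2ccc(Br)c(O)c2)C1=O`, compound 2 is `CCOC(=O)C1=C(Nc2ccccc2)S/C(=C\c2cc(OC)ccc2OC)C1=O` and compound 3 is `CCOC(=O)C1=C(Nc2ccccc2)S/C(=C\c2ccc(C(=O)OCC)[nH]2)C1=O`. In a functional assay on K562 cells (Homo sapiens) for inhibition, read by MTT assay, with a stated time of 72 h, tested at 10 uM (a higher number here means more inhibition at the concentration tested (going by the name of the read-out), a lower number less inhibition), compound 1 gives 22%; in this assay compound 2 gives 30.7% and compound 3 gives 18.6%. Compound 1 stands in the middle of these three numbers, but its gap to compound 3 and its gap to compound 2 both lie within the usual scatter of this assay, so the three compounds cannot be told apart on the numbers shown.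

Compound 4 is `CCOC(=O)C1=C(Nc2ccccc2)S/C(=C\c2cc3ccncc3[nH]2)C1=O`. It differs from compound 1 in one place: a group of 9 heavy atoms (7 carbon, 2 nitrogen; one five-membered aromatic ring with 1 hetero atom, one six-membered aromatic ring with 1 hetero atom) in place of a group of 8 heavy atoms (6 carbon, 1 oxygen, 1 bromine; one six-membered aromatic ring of carbon only), on a double-bonded chain carbon bound to a double-bonded ring carbon. Going by the values given here, no measured pair in this set shows a change of this kind, so the size and direction of the step from compound 1 to compound 4 cannot be read from the data. Since the three aromatic groups measured so far all give numbers within the scatter of each other, the new group is expected to give a number that is again within the scatter of compound 1, with no step beyond it, and compound 4 is therefore estimated at 24%, between 8% and 45%, which means an expected step of a number 2 percentage points higher from compound 1 to compound 4 (within the scatter).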

Compound 4, a percentage reported as inhibition, at one concentration (the size of the read-out at that concentration, not a potency): 22.8%
Compound 4: middle estimate off by 1.2 percentage points, on the high side; low and high end bracket the measured number.
By their numbers in this assay, from the lowest: compounds 3, 1, 4 and 2 (each within the scatter of the next, the first and the last beyond it).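

In this assay the 4-bromo-3-hydroxyphenyl group, on a double-bonded chain carbon bound to a double-bonded ring carbon, gives way to a group with one five-membered and one six-membered aromatic ring, and the result is a number 0.8 percentage points higher from compound 1 to compound 4 (within the scatter). Going by these compounds alone, this single-place comparison shows that exchanging a carbon-only ring for this two-ring group with 2 nitrogen atoms, while the hydrogen-bond donor and acceptor counts stay the same, produces no step that can be told from the scatter at the one concentration tested. Nothing measured here offers an explanation for this result.

The pair says nothing about a group of a different kind at this place, such as a carboxylic acid or an amine carried on a longer chain, and whether either would move the number beyond the scatter remains an open question. It also leaves open what a change elsewhere on the shared core would do, for example replacing the ethyl ester or the phenyl ring on the amine nitrogen, since both stay the same in every compound shown.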